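Chloro to Methyl on a Second Fused Core

The source may hold more compounds than are shown below. What is called first, only, known or untested is meant among the compounds shown, and "the series" means these compounds.

Measured so far, in a functional assay on KBVIN cells (Homo sapiens) for cytotoxicity, read by sulforhodamine B assay; on this read-out lower numbers stand for stronger inhibition of growth and higher numbers for weaker inhibition of growth:
Compound 1 `COc1ccc2c(c1)CCN2c1nc(Cl)nc2ccccc12` gives 197 nM.
Compound 2 `COc1ccc2c(c1)CCN2c1nc(C)nc2ccccc12` gives 216 nM.
Compound 3 `COc1ccc2c(c1)CCCN(c1nc(Cl)nc3ccccc13)C2` gives 5450 nM.

Compounds 1 and 2 share one core and differ in a single place: methyl in place of chloro on an aromatic carbon. That change produced a 1.1-fold higher number from compound 1 to compound 2 (0.04 log units; within the scatter), so the two compounds cannot be told apart by this read-out. Compound 3 is built on a different core, and the difference between the two cores is not broken down here. Compound 3 has the highest number of the three, and its gaps to compound 1 and to compound 2 both lie beyond the usual scatter, so it inhibits growth more weakly than either.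

Compound 4 `COc1ccc2c(c1)CCCN(c1nc(C)nc3ccccc13)C2` has not yet been measured in this assay. It differs from compound 3 by methyl in place of chloro on an aromatic carbon, and the surroundings of that place are described in the same words as for the change from compound 1 to compound 2, so this is the same change made on the core of compound 3. On the core of compound 1 that change gave a 1.1-fold higher number from compound 1 to compound 2 (0.04 log units; within the scatter), and on that basis compound 4 is expected to stay close to compound 3, with an expected step of a 1.1-fold higher number from compound 3 to compound 4 (0.04 log units; within the scatter) in this assay. The estimate for compound 4 is 6000 nM, expected to fall between 2500 nM and 14000 nM.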

Compound 4, concentration for 50% growth inhibition: 14800 nM
Beside the measured number, compound 4's estimate is 2.5-fold (0.39 log units) below it; measured number above the stated range.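

In this assay, methyl in place of chloro gave a 2.7-fold higher number from compound 3 to compound 4 (0.43 log units; beyond the scatter), a modest step, whereas on the core of compound 1 the same change gave a 1.1-fold higher number from compound 1 to compound 2 (0.04 log units; within the scatter). One step lies beyond the usual scatter and the other within it, yet set side by side they cannot be told apart, so as far as this read-out can tell, the change carries over from one core to the other: the same change on two cores in this assay, a 1.1-fold higher number (0.04 log units; within the scatter) from compound 1 to compound 2 and a 2.7-fold higher number (0.43 log units; beyond the scatter) from compound 3 to compound 4, 2.5-fold (0.39 log units) apart, within the scatter of two such steps. This does not prove that the two cores respond identically, since a real but small difference could be hidden in the scatter, and two pairs say nothing about why the numbers moved or how the change would behave on a third core.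

As far as these compounds go, all four compounds carry either chloro or methyl on the aromatic carbon between two ring nitrogen atoms, so it remains open how an amine, a nitrile or a longer chain such as ethyl would fare at that place. Also open is which part of the difference between the two cores accounts for the higher numbers of compound 3 and compound 4, since the two cores differ in more than one place.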